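The source may report more compounds than this note shows. Statements on the series, on what has been measured and on what is new or still open speak of the compounds shown alone.

Measured so far in an ADME assay on BJ cells (Homo sapiens), read by MTT assay, with a stated time of 72 h; a lower number here means a stronger inhibitor, a higher number a weaker inhibitor:
compound 1, `C#Cc1cn([C@@H]2O[C@H](CO)[C@@H](O)[C@H]2O)c2ncnc(NC)c12`: 86000 nM
compound 2, `C#Cc1cn([C@@H]2O[C@H](CO)[C@@H](O)[C@H]2O)c2nc(N)nc(OC)c12`: > 100000 nM

Both are weak inhibitors in this assay. Compound 1 gives a number, 86000 nM. For compound 2 the assay returns only a limit, > 100000 nM, so where compound 2 stands among the numbers is known only as the limit of > 100000 nM in this assay, at which 1 of the 2 values shown sits, and no value can be put on it.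

Compound 3, `C#Cc1cn([C@@H]2O[C@H](CO)[C@@H](O)[C@H]2O)c2ncnc(OC)c12`, is not yet measured. It differs from compound 2 in one place: hydrogen in place of amino on an aromatic carbon. Within the data shown here, no step between two measured compounds is available to size this kind of change, and compound 2 offers only a limit as a starting point, so the step cannot be anchored. The expectation for this assay is no step beyond the scatter, the estimated change being a number no higher from compound 2 to compound 3 (the limit leaves the size open). Compound 3 is therefore estimated at 100000 nM in this assay, with a range from 40000 nM to 300000 nM, and a sizeable chance that only a limit is reported again.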

Compound 3, half-maximal inhibitory concentration: 98400 nM
Compound 3: middle estimate off by 1.0-fold (0.01 log units), on the high side; low and high end bracket the measured number.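

On these data alone, with hydrogen in place of amino on the aromatic carbon between two ring nitrogen atoms, this assay returns a number for the methoxy compound, but the step reads only as an at least 1.0-fold lower number from compound 2 to compound 3 (0.00 log units; that floor lies within the scatter), so the size of this change stays open. Methoxy in place of methylamino on an aromatic carbon gives a 1.1-fold higher number from compound 1 to compound 3 (0.06 log units; within the scatter), the first step in the series with a number at both ends, and this exchange does not move the read-out beyond the scatter. Compound 2 holds only a limit of the assay, so the contribution of amino cannot be sized: the limit of > 100000 nM in this assay, at which 1 of the 3 values shown sits.

The compounds shown leave open whether a longer chain or a carboxylic acid in place of methoxy would separate from these weak values. They also leave open whether a methyl group on the carbon between two ring nitrogen atoms would give a number distinct from compound 3.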